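Aryl exchange from compound 2 to compound 4

The source may report more compounds than this note shows. Statements on the series, on what has been measured and on what is new or still open speak of the compounds shown alone.

Values in a functional assay on MCF7 cells (Homo sapiens) for antiproliferative activity, read by MTT assay, with a stated time of 48 h (on this read-out lower numbers stand for stronger inhibition and higher numbers for weaker inhibition), are as follows
compound 1 `COC(=O)/C(=C/c1ccccc1)CN1C(=O)[C@@H](OC)[C@H]1c1cccc(Cl)c1` gives 25100 nM
compound 2 `CCOC(=O)/C(=C/c1ccccc1)CN1C(=O)[C@@H](OC)[C@H]1c1cccc([N+](=O)[O-])c1` gives 19900 nM
compound 3 `COC(=O)/C(=C/c1ccccc1)CN1C(=O)[C@@H](OC)[C@H]1c1cccc(F)c1` gives 13700 nM

Compound 2 at 19900 nM lies within the scatter of both other compounds, so the three values form one band without a meaningful order. The next compound is compound 4 `CCOC(=O)/C(=C/c1ccccc1)CN1C(=O)[C@@H](OC)[C@H]1c1ccc(F)cc1`, which has not yet been measured. Its difference from compound 2 is 4-fluorophenyl in place of 3-nitrophenyl on a saturated ring carbon and amounts to 4-fluorophenyl in place of 3-nitrophenyl on a saturated ring carbon, next to the ring nitrogen.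

Going by the values given here, the only measured step that bears on this aryl group is a 1.8-fold lower number from compound 1 to compound 3 (0.26 log units; within the scatter) and it stays within the scatter. That step exchanges chloro for fluoro on an aromatic carbon. Among the compounds with values here, no measured compound carries the 4-fluorophenyl group, so the data leave this exact change untested. On the evidence of the small step to compound 3 at 13700 nM no step beyond the scatter is expected in this assay and no firm direction can be given. The expected step is a 1.1-fold lower number from compound 2 to compound 4 (0.04 log units; within the scatter) and nothing larger is anticipated. For compound 4 the estimate is 18000 nM with an expected range from 8000 nM to 40000 nM in this read-out.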

Compound 4, half-maximal inhibitory concentration: 18800 nM
The estimate for compound 4 lay 1.0-fold (0.02 log units) below the measured number, within the range that was stated.
By their numbers in this assay, from the lowest: compounds 3, 4, 2 and 1 (each within the scatter of the next).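

In this assay, replacing 3-nitrophenyl with 4-fluorophenyl on the saturated ring carbon next to the ring nitrogen gives a 1.1-fold lower number from compound 2 to compound 4 (0.02 log units; within the scatter). This is a larger exchange than the earlier swap of chloro for fluoro. The substituent and its place on the aromatic ring change together and the hydrogen-bond acceptors counted on 3-nitrophenyl are absent from 4-fluorophenyl, yet the step stays within the scatter, so this read-out does not separate the two aryl groups on the shared core of compound 2 and compound 4. No measurement at hand offers an explanation for this flat result.

Because the substituent and its place on the ring changed in one step, the contribution of each remains unresolved, and 3-fluorophenyl and 4-fluorophenyl on the ethyl ester would be needed to separate them. Also open, on these data alone, is whether a more different group at this position, such as an aminophenyl group, a carboxyphenyl group or a cyclohexyl group in place of the aromatic ring, would shift the number beyond the scatter.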